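Side-chain exchange on the aryloxy chain of compound 2

The source may report more compounds than this note shows. Statements on the series, on what has been measured and on what is new or still open speak of the compounds shown alone.

Compound 1 `COc1ccc(-c2cc(-c3ccccc3)no2)c(OCC(=O)O)c1` gives 11.7% in a functional assay on the whole organism (blood, strain Charles Foster/Wistar albino) with Rattus norvegicus as the target, with a stated time of 30 min, at a dose of 100 mg/kg by the oral route (a higher number here means more inhibition at the dose given (going by the name of the read-out), a lower number less inhibition), and compound 2 `CCOC(=O)CCCOc1cc(OC)ccc1-c1cc(-c2ccccc2)no1` gives 4.6% in this assay; the two numbers sit within the scatter of each other, so compound 2 is not separated from compound 1. Among the compounds with values here, the only measured step, a number 7.1 percentage points lower from compound 1 to compound 2 (within the scatter), altered the same chain position. Compound 3 `CCN(CC)CC(O)COc1cc(OC)ccc1-c1cc(-c2ccccc2)no1` differs from compound 2 by 2-(diethylamino)-1-hydroxyethyl in place of 2-(ethoxycarbonyl)ethyl on a saturated chain carbon bound to an oxygen on an aromatic ring. Within the data shown here, no measured step covers this exchange, and the single step available stayed within the scatter, so no step beyond the scatter is expected, a number 3.4 percentage points higher from compound 2 to compound 3 (within the scatter). Compound 3 is therefore estimated at 8%, between 0% and 25%.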

Compound 3, a percentage reported as inhibition, in the whole organism at one dose (the size of the read-out at that dose, not a potency): 13.8%
Beside the measured number, compound 3's estimate is 5.8 percentage points below it; the range from low to high includes it.
By their numbers in this assay, from the lowest: compounds 2, 1 and 3 (each within the scatter of the next).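

In this assay the basic-amine side chain, 2-(diethylamino)-1-hydroxyethyl, can replace 2-(ethoxycarbonyl)ethyl on a saturated chain carbon bound to an oxygen on an aromatic ring (a number 9.2 percentage points higher from compound 2 to compound 3 (within the scatter)) and can replace carboxy there too (a number 2.1 percentage points higher from compound 1 to compound 3 (within the scatter)). An acid, an ester and an amino alcohol at this position therefore remain unseparated at the single dose. No evidence on the cause of these numbers is available. From the compounds shown here alone, whether a primary amine, an amide or a longer chain at this position would separate from these three stays open.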